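A few compounds are considered here, and "the series" means these few. Any claim that something is new, unique, unknown or untested is made for them only; others in the source may bear on it.

Within the data shown here, in a functional assay on Jurkat cells (Homo sapiens) for antiproliferative activity, read by MTT assay, with a stated time of 72 h (a lower number here means a stronger inhibitor, a higher number a weaker inhibitor), compound 1 `COc1ccc(-c2c(C(=O)c3cc(OC)c(OC)c(OC)c3)sc3ccccc23)cc1` gives 1600 nM and compound 2 `COc1cc(C(=O)c2sc3ccccc3c2Nc2ccccc2)cc(OC)c1OC` gives 1600 nM as well, so compound 2 stands level with compound 1 on the numbers so far. Compound 3 `COc1cc(C(=O)c2sc3ccccc3c2Nc2ccc(Cl)cc2)cc(OC)c1OC` differs from compound 2 by one small edit (chloro in place of hydrogen on an aromatic carbon) in which chloro takes the place of hydrogen on an aromatic carbon, para to a large group. This turns anilino into (4-chlorophenyl)amino.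

Among the measured compounds shown here, only one measured step exists to guide a forecast. It is no change at the digits printed from compound 1 to compound 2 (within the scatter) for anilino in place of 4-methoxyphenyl on an aromatic carbon. That step bears on the new edit only loosely, since it exchanged a whole group, while the new edit adds a single chlorine atom. For the measured compounds named here, no measured compound carries chloro, so the data favour no direction. With so little to go on, the forecast in this assay stays close to compound 2 at 1600 nM for now. The expected step is no change at the digits printed from compound 2 to compound 3 (within the scatter) and it carries wide uncertainty. The estimated value for compound 3 is 1600 nM with an expected range from 500 nM to 5000 nM in this estimate.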

Compound 3, half-maximal inhibitory concentration: 1900 nM
Estimate against measurement, compound 3: 1.2-fold (0.07 log units) below, within the range that was stated.
By their numbers in this assay, from the lowest: compounds 1, 2 and 3 (each within the scatter of the next).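

In this assay, putting a single chlorine atom on the six-membered aromatic ring of the anilino group, para to a large group, gives a 1.2-fold higher number from compound 2 to compound 3 (0.07 log units; within the scatter) and so leaves the number unmoved in any readable way. Among these compounds, this is the first look at a small edit on this ring, as the earlier comparison exchanged a whole group, and it shows that the position accepts a chloro in place of hydrogen without a change that stands out from the usual scatter of repeated measurements. The wider exchange of 4-methoxyphenyl for (4-chlorophenyl)amino gives a 1.2-fold higher number from compound 1 to compound 3 (0.07 log units; within the scatter) and is just as flat, so all three compounds remain indistinguishable in this test, and no measurement at hand offers a reason for that.

On these data alone, one chloro at one place is a narrow sample, so it remains open whether a methyl, a nitrile, an amine or a carboxylic acid at this same place would also leave the number where it is. As far as these compounds go, it is equally open whether a chloro elsewhere on that ring would behave as this one does.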